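Ester-to-ether swap on the 4-arylpiperidine series

The source may report more compounds than this note shows. Statements on the series, on what has been measured and on what is new or still open speak of the compounds shown alone.

Three compounds of the shared core carry a measured number in an assay on striatum with sodium-dependent dopamine transporter (Rattus norvegicus) as the target; on this read-out lower numbers stand for stronger inhibition and higher numbers for weaker inhibition. Compound 1 `CN1CC[C@H](c2ccc(Cl)cc2)[C@@H](C(=O)OC(C)(C)C)C1` gives 318 nM. Compound 2 `CN1CC[C@H](c2ccc(Cl)cc2)[C@@H](C(=O)OCCCCCc2ccccc2)C1` gives 53 nM, and compound 3 `CN1CC[C@H](c2ccc(Cl)cc2)C(C(=O)Oc2ccccc2)C1` gives 906 nM. Among these three numbers compound 1 stands second highest: the nearest is compound 3, with a higher number beyond the scatter, and the furthest is compound 2, with a lower number beyond the scatter. Among the compounds with values here, all three differ from each other only in the group on the ester oxygen, so no single step between them is isolated for this exercise.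

Compound 4 `C=CCOC[C@H]1CN(C)CC[C@@H]1c1ccc(Cl)cc1` has not yet been measured in this assay. Compared with compound 1 the change is (allyloxy)methyl in place of tert-butoxycarbonyl on a saturated ring carbon; in words, (allyloxy)methyl in place of tert-butoxycarbonyl on a saturated ring carbon, next to the ring atom that bears a 4-chlorophenyl group. Within the data shown here, no measured pair shows what removing the carbonyl from this position does, so the expectation rests on compound 1 alone. The step from compound 1 to compound 4 is expected to be small, a modestly lower number that may still fall within the scatter, as a 1.6-fold lower number from compound 1 to compound 4 (0.20 log units; within the scatter) states. Compound 4 is therefore estimated at 200 nM, with a range from 60 nM to 700 nM.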

Compound 4, inhibition constant: 60 nM
Compound 4: the middle estimate sits 3.3-fold (0.52 log units) above what was measured, and the stated range covers the measured number.
By their numbers in this assay, from the lowest: compounds 2 and 4 (each within the scatter of the next); then compound 1; then compound 3.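

In this assay, replacing tert-butoxycarbonyl with (allyloxy)methyl on this saturated ring carbon gives a 5.3-fold lower number from compound 1 to compound 4 (0.72 log units; beyond the scatter) and shows that an ester carbonyl at this position is not required for a number in the range of the esters. Compound 2 at 53 nM and compound 4 at 60 nM lie within the usual scatter of each other, so a group of 5 heavy atoms with 1 hydrogen-bond acceptor matches the value of the long phenyl-bearing ester of compound 2 in this series. No measured evidence here bears on why the step has this size.

Still open, as far as these compounds go, is what the ether oxygen itself contributes: a plain propyl or butyl chain, a hydroxymethyl group or an aminomethyl group on the same carbon would separate the oxygen from the rest of the chain. Also open, from the compounds shown here alone, are whether the double bond of the allyl group matters, which a propoxymethyl group would test, and whether a longer ether chain ending in phenyl, the ether counterpart of compound 2, would follow the same direction as the step from the tert-butyl ester.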